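From pyridin-2-yl to pyrimidin-2-yl on the carbonyl

This account rests on a few compounds, and the source may have more. Where it says the series, first, only, none or still open, it means among the compounds named here.

Measured in an ADME assay on microsomes from liver (Mus musculus) for pharmacokinetics; a higher number here means faster removal of the compound, a lower number slower removal:
- Compound 1 `COCC(=O)N[C@@H](C)c1ccc(NC(=O)[C@H]2C[C@@H]2c2cccnc2)cc1`: 43.2 mL.min-1.g-1
- Compound 2 `C[C@H](NC(=O)c1ccccn1)c1ccc(NC(=O)[C@H]2C[C@@H]2c2cccnc2)cc1`: < 3.42 mL.min-1.g-1 (a limit, not a number)

Compound 2 stands at the limit of < 3.42 mL.min-1.g-1 in this assay, at which 1 of the 2 values shown sits, which is a limit of the assay and not a number. Compound 3 `C[C@H](NC(=O)c1ncccn1)c1ccc(NC(=O)[C@H]2C[C@@H]2c2cccnc2)cc1` carries pyrimidin-2-yl in place of pyridin-2-yl on a carbonyl carbon. For the measured compounds named here, only one measured step bears on this place, the large at least 12-fold lower number from compound 1 to compound 2 (1.10 log units; beyond the scatter), where a ring took the place of methoxymethyl. Here one six-membered aromatic ring follows another, so a far smaller step is expected in this assay, probably within the scatter and without a clear direction. The estimated step is a step that the limit leaves unreadable from compound 2 to compound 3. For compound 3 the estimated value is 3.4 mL.min-1.g-1, with an expected range of 1.5 mL.min-1.g-1 to 9 mL.min-1.g-1.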

Compound 3, intrinsic clearance in microsomes: 38.4 mL.min-1.g-1
The estimate for compound 3 lay 11-fold (1.05 log units) below the measured number, outside the stated range (above it).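

In this assay, the step of an at least 11-fold higher number from compound 2 to compound 3 (1.05 log units; beyond the scatter) shows that exchanging one six-membered aromatic ring for another on this carbonyl carbon can matter greatly. Having a ring here is not enough for slow removal, as the step of a 1.1-fold lower number from compound 1 to compound 3 (0.05 log units; within the scatter) shows with pyrimidin-2-yl in place of methoxymethyl. The value for compound 2 is a limit, not a number: the limit of < 3.42 mL.min-1.g-1 in this assay, at which 1 of the 3 values shown sits.

Still open, from the compounds shown here alone, is whether the slow removal is specific to pyridin-2-yl, or whether another ring on the carbonyl carbon, such as phenyl, would share it.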